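Two stereoisomeric lactones and a third configuration to estimate

The compounds below may be only part of what the source reports. "The series", "measured", "known", "first", "only" and "open" are said of these compounds alone.

Compound 1 `CCCCC[C@@H](C[C@H](O)C[C@@H]1CC=CC(=O)O1)OC` gives 26300 nM in a functional assay on A2780 ADR cells (Homo sapiens) for cytotoxicity, read by MTT assay, with a stated time of 24 h; a higher number here means a weaker inhibitor, a lower number a stronger inhibitor.
Compound 2 `CCCCC[C@H](C[C@@H](O)C[C@@H]1CC=CC(=O)O1)OC` gives 91500 nM in this assay.

Of the two measured compounds, compound 1 has the lower number, and compound 2 lies a 3.5-fold higher number from compound 1 to compound 2 (0.54 log units; beyond the scatter) away. The two share all atoms and bonds, and the only thing that separates them is the fact that compounds 1 and 2 differ only in the configuration as drawn, so the gap between them shows how much a change in configuration alone can move the result in this assay.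

Compound 3 `CCCCC[C@H](C[C@H](O)C[C@H]1CC=CC(=O)O1)OC` has not yet been measured. Against compound 1 it shows (the two compounds have the same atoms and bonds and differ only in configuration as drawn: 2 of 3 stereo elements differ; a stereocentre at a saturated chain carbon is drawn S in compound 1 and R in compound 3; a stereocentre at a saturated ring carbon is drawn S in compound 1 and R in compound 3). Among the compounds with values here, the one measured step that bears on this change is the step from compound 1 to compound 2, where inverting two stereocentres gave a 3.5-fold higher number from compound 1 to compound 2 (0.54 log units; beyond the scatter), a modest shift toward a weaker inhibitor. Compound 3 inverts a different pair of centres, one in the chain and one in the ring, so the size need not match, but a rise of similar order seems the most likely outcome. Compound 3 is therefore expected to give about 60000 nM in this assay, within a range from 20000 nM to 180000 nM. That estimate corresponds to an expected step of a 2.3-fold higher number from compound 1 to compound 3 (0.36 log units; beyond the scatter).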

Compound 3, half-maximal inhibitory concentration: 57500 nM
For compound 3 the middle estimate is 1.0-fold (0.02 log units) above the measured one; low and high end bracket the measured number.
By their numbers in this assay, from the lowest: compound 1; then compounds 3 and 2 (each within the scatter of the next).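

In this assay, within the data shown here, the new step brings in a saturated ring carbon for the first time. Inverting it together with a saturated chain carbon also moves the number beyond the scatter, giving a 2.2-fold higher number from compound 1 to compound 3 (0.34 log units; beyond the scatter). Compound 1 therefore has the lowest number of the three, since its steps to both other stereoisomers lie beyond the scatter, and that separation from compound 3 can come only from stereochemistry: the fact that compounds 1 and 3 differ only in the configuration as drawn
Compound 2 and compound 3 differ from each other at two stereo elements, yet the gap between them does not exceed the scatter, at a 1.6-fold lower number from compound 2 to compound 3 (0.20 log units; within the scatter).

From the compounds shown here alone, each of these steps changes two stereo elements at once, so the share of any single centre, including the saturated ring carbon, remains unknown. The compounds shown also leave open how the number would respond to a change of atoms rather than configuration, such as an amine in place of the hydroxyl group or a longer chain on the shared core.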